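Thiophen-3-yl for thiophen-2-yl in a cytotoxic series

The compounds below may be only part of what the source reports. "The series", "measured", "known", "first", "only" and "open" are said of these compounds alone.

In a functional assay on DU-145 cells (Homo sapiens) for cytotoxicity, read by CCK-8 assay (on this read-out lower numbers stand for stronger inhibition and higher numbers for weaker inhibition), compound 1 (`Oc1ccc(-c2cc(-c3cccs3)cc(-c3ccccc3O)n2)cc1`) reads > 50000 nM as a limit of the assay. Going by the values given here, compound 2 (`Oc1ccc(-c2cc(-c3cccs3)cc(-c3cccc(O)c3)n2)cc1`) gives 1890 nM as the only actual number so far. Among the compounds with values here, the single measured step of an at least 26-fold lower number from compound 1 to compound 2 (1.42 log units; beyond the scatter) is large, but it swaps a hydroxyphenyl group and not the thiophene, so it does not size the change ahead. Compound 3 (`Oc1ccc(-c2cc(-c3ccsc3)cc(-c3cccc(O)c3)n2)cc1`) carries thiophen-3-yl in place of thiophen-2-yl, opposite the ring nitrogen (thiophen-3-yl in place of thiophen-2-yl on an aromatic carbon). No step beyond the scatter is expected in this assay here. The expected step is a 1.1-fold higher number from compound 2 to compound 3 (0.02 log units; within the scatter) in this assay's terms. Compound 3 is estimated at 2000 nM within a range of 800 nM to 5500 nM for now.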

Compound 3, half-maximal inhibitory concentration: 2230 nM
Compound 3: middle estimate off by 1.1-fold (0.05 log units), on the low side; low and high end bracket the measured number.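

Moving the point of attachment, with thiophen-3-yl in place of thiophen-2-yl, gives a 1.2-fold higher number from compound 2 to compound 3 (0.07 log units; within the scatter) in this assay. At this position, opposite the ring nitrogen, the two thiophene forms therefore cannot be told apart on this read-out, although the same atoms are joined differently. From the compounds shown here alone, whether an amine, a carboxylic acid or a longer chain at this position would leave the number in the same range stays open, as does whether the thiophene change reads the same with the 2-hydroxyphenyl group of compound 1. Nothing given here bears on a cause for this result.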